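Sulfamoyl for fluoro on the triazole aryl of compound 2

This account rests on a few compounds, and the source may have more. Where it says the series, first, only, none or still open, it means among the compounds named here.

Compound 2 `N#CC1=C(N)Oc2c(c3nc4ccccc4nc3c3ccccc23)C12C(=O)N(Cc1cnnn1-c1ccc(F)cc1)c1ccccc12` in a functional assay on HepG2 cells (Homo sapiens) for antiproliferative activity, read by MTT assay, with a stated time of 48 h (on this read-out higher numbers stand for weaker inhibition and lower numbers for stronger inhibition), gives only a limit, > 50000 nM. Compound 1 `Cc1ccccc1-n1nncc1CN1C(=O)C2(C(C#N)=C(N)Oc3c2c2nc4ccccc4nc2c2ccccc32)c2ccccc21` likewise returns a limit in this assay, > 50000 nM. For the measured compounds named here, the one measured step, a step that the two limits leave unreadable from compound 1 to compound 2, has no readable size; the limit of > 50000 nM in this assay, at which 2 of the 2 values shown sit, marks where both values sit. Compound 3 `N#CC1=C(N)Oc2c(c3nc4ccccc4nc3c3ccccc23)C12C(=O)N(Cc1cnnn1-c1ccc(S(N)(=O)=O)cc1)c1ccccc12` differs from compound 2 by sulfamoyl in place of fluoro on an aromatic carbon. Going by the values given here, no measured step bears on this change; the step is expected as a number no higher from compound 2 to compound 3 (the limit leaves the size open), with no direction readable from the data. Compound 3 is estimated at 50000 nM, in a range from 15000 nM to 150000 nM, most probably reported again as a limit.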

Compound 3, half-maximal inhibitory concentration: 42200 nM
For compound 3 the middle estimate is 1.2-fold (0.07 log units) above the measured one; the measured number falls inside the stated range.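

In this assay, compound 3 is the only one of the three to return a number rather than a limit, so this aryl position accepts sulfamoyl with a readable result. Sulfamoyl for fluoro gives an at least 1.1-fold lower number from compound 2 to compound 3 (0.07 log units; that floor lies within the scatter), and 4-sulfamoylphenyl for 2-methylphenyl gives an at least 1.1-fold lower number from compound 1 to compound 3 (0.07 log units; that floor lies within the scatter). The other two compounds remain at: the limit of > 50000 nM in this assay, at which 2 of the 3 values shown sit.

From the compounds shown here alone, the true size of both steps stays open, since only their floors are known. Also open, going by these compounds, is whether a carboxylic acid or an amine at the same place would move the number further.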